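A Methoxy Group Enters Where Chloro Stood

A few compounds are considered here, and "the series" means these few. Any claim that something is new, unique, unknown or untested is made for them only; others in the source may bear on it.

Of the compounds shown here, three built on one shared core have been tested for antiproliferative activity in an ADME assay on HUVEC cells (Homo sapiens) for antiproliferative activity, read by MTT assay, with a stated time of 48 h; a lower number here means a stronger inhibitor, a higher number a weaker inhibitor. Compound 1 `Cc1cccc(-n2nncc2CN2C(=O)C3(C(C#N)=C(N)Oc4c3c3nc5ccccc5nc3c3ccccc43)c3ccccc32)c1` carries a 3-methylphenyl group on an aromatic nitrogen. In this assay compound 1 gives > 50000 nM, which is a limit of the assay rather than a number. Compound 2 `N#CC1=C(N)Oc2c(c3nc4ccccc4nc3c3ccccc23)C12C(=O)N(Cc1cnnn1-c1ccc(Cl)cc1)c1ccccc12` carries 4-chlorophenyl in place of 3-methylphenyl on that nitrogen. In this assay compound 2 gives > 50000 nM, again only a limit. Compound 3 `N#CC1=C(N)Oc2c(c3nc4ccccc4nc3c3ccccc23)C12C(=O)N(Cc1cnnn1-c1ccccc1Br)c1ccccc12` carries 2-bromophenyl there instead. In this assay compound 3 gives > 50000 nM, once more a limit. Because all three values sit at the limit of > 50000 nM in this assay, at which 3 of the 3 values shown sit, the steps a step that the two limits leave unreadable from compound 1 to compound 2, a step that the two limits leave unreadable from compound 1 to compound 3 and a step that the two limits leave unreadable from compound 2 to compound 3 cannot be read in size or direction. Compound 2 thus stands at the limit, with nothing measured to place it among the others.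

Compound 4 `COc1ccc(-n2nncc2CN2C(=O)C3(C(C#N)=C(N)Oc4c3c3nc5ccccc5nc3c3ccccc43)c3ccccc32)cc1` is the next case. It differs from compound 2 by methoxy in place of chloro on an aromatic carbon. Within the data shown here, none of the measured steps can be read, so none offers a guide. Every change so far on this aromatic nitrogen left the value at the limit, so the step expected, a step that the limit leaves unreadable from compound 2 to compound 4, lies within the usual scatter. Compound 4 is therefore estimated to give 60000 nM in this assay, between 30000 nM and 200000 nM, most likely reported again as a limit.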

Compound 4, half-maximal inhibitory concentration: > 50000 nM
Compound 4: only a limit was reported; the forecaster's own chance of this, stated with the estimate: 85%; the middle value is on the limit's open side.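

In this assay compound 4 gives > 50000 nM as a limit of the assay, not a number. The steps to compound 4 from compound 1, compound 2 and compound 3 cannot be read in size or direction, because every value rests on the same limit: the limit of > 50000 nM in this assay, at which 4 of the 4 values shown sit. The compounds shown leave open how strongly any of the four compounds acts, and whether the groups on the aromatic nitrogen differ at all.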